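Amide aryl size and acyltransferase inhibition

The source may hold more compounds than are shown below. What is called first, only, known or untested is meant among the compounds shown, and "the series" means these compounds.

compound 1, `CCCCCCCCCCC(C)(C)NC(=O)c1c(OC)cc(OC)cc1OC` — an assay on microsomes from liver for inhibition of sterol O-acyltransferase 1 (Rattus norvegicus); a lower number here means a stronger inhibitor, a higher number a weaker inhibitor: > 10000 nM
compound 2, `CCCCCCCCCCCCn1nnc(C(NC(=O)c2c(C(C)C)cccc2C(C)C)c2ccccc2)n1` — this assay : 810 nM

In this assay compound 1 reaches only the limit > 10000 nM, which is a limit of the measurement and not a number. In this assay, among the compounds with values here, compound 2 gives 810 nM, the only number in the set, since the limit of > 10000 nM in this assay, at which 1 of the 2 values shown sits, is the other entry; compound 2 therefore stands alone and cannot be ranked against anything measured.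

Compound 3 `CCCCCCCCCCCCn1nnc(C(NC(=O)c2c(C)cccc2C)c2ccccc2)n1` differs from compound 2 in one place: 2,6-dimethylphenyl in place of 2,6-diisopropylphenyl on a carbonyl carbon. Within the data shown here, no measured pair in the set shows a change of this kind, so its size has no precedent here. The step expected is a 4.9-fold higher number from compound 2 to compound 3 (0.69 log units; beyond the scatter), a loss beyond the scatter. Compound 3 is expected in this assay at 4000 nM. The lower end expected for compound 3 is 1500 nM. The upper end expected for compound 3 is 15000 nM, with a fair chance that only a limit is reported.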

Compound 3, half-maximal inhibitory concentration: 310 nM
The estimate for compound 3 lay 13-fold (1.11 log units) above the measured number; measured number outside the range, below it.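

Replacing 2,6-diisopropylphenyl with 2,6-dimethylphenyl on a carbonyl carbon gives, in this assay, a 2.6-fold lower number from compound 2 to compound 3 (0.42 log units; beyond the scatter). At this position, the larger of the two groups is therefore not required for inhibition in this range, and the smaller group gives the stronger inhibitor of this pair. Nothing on hand bears on the reason for this step.

As far as these compounds go, this single pair sets no trend, so it remains open whether a plain phenyl, with neither flanking alkyl group, would continue the gain or lose it. Also open, from the compounds shown here alone, is how this carbonyl position responds to groups of another kind, such as a pyridine ring or an aryl ring carrying a carboxylic acid or an amine.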